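Halogen swap on the sulfonyl aryl ring: cytotoxicity notes

A few compounds are considered here, and "the series" means these few. Any claim that something is new, unique, unknown or untested is made for them only; others in the source may bear on it.

Compound 1 `N#Cc1c(N)cccc1S(=O)(=O)c1ccccc1Br` gives 40000 nM in a functional assay on MT4 cells (Homo sapiens) for cytotoxicity; on this read-out lower numbers stand for stronger inhibition and higher numbers for weaker inhibition.
Compound 3 `N#Cc1c(N)cccc1S(=O)(=O)c1ccccc1F` gives 57000 nM in this assay.
Compound 2 `N#Cc1c(N)cccc1S(=O)(=O)c1cccc(Br)c1` reaches only the limit > 200000 nM in this assay, a limit of the assay and not a number.

Compound 1 and compound 2 share the same atoms joined differently; the difference between the two cores is not broken down here. Within the data shown here, the one measured step is fluoro in place of bromo on an aromatic carbon, which gave a 1.4-fold higher number from compound 1 to compound 3 (0.15 log units; within the scatter). The same kind of change is made from compound 2 to compound 4 `N#Cc1c(N)cccc1S(=O)(=O)c1cccc(F)c1`, not yet measured: fluoro in place of bromo on an aromatic carbon. The two places are not the same: in the first case the carbon is ortho to a large group, in the second meta to a large group.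

On these data alone, compound 2 stands at the limit of > 200000 nM in this assay, at which 1 of the 3 values shown sits, so the number itself is unknown. Given that the measured step was a 1.4-fold higher number from compound 1 to compound 3 (0.15 log units; within the scatter), a step of similar size is expected from compound 2 to compound 4, that is a step that the limit leaves unreadable from compound 2 to compound 4, and compound 4 is then expected to sit at or beyond the limit as well. The estimate for compound 4 is 250000 nM, expected to fall between 100000 nM and 600000 nM.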

Compound 4, half-maximal inhibitory concentration: > 200000 nM
Compound 4 gave a limit, no number (the forecaster's own chance of this, stated with the estimate: 75%); the middle value is on the limit's open side.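

In this assay compound 2 and compound 4 each give a limit and not a number, so no step between them can be read: the limit of > 200000 nM in this assay, at which 2 of the 4 values shown sit.

Left open is where compound 2 and compound 4 truly sit, and so whether fluoro in place of bromo meta to a large group compares with the same change between compound 1 and compound 3.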